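The source may hold more compounds than are shown below. What is called first, only, known or untested is meant among the compounds shown, and "the series" means these compounds.

In a functional assay on NALM-6 cells (Homo sapiens) (a lower number here means a stronger inhibitor, a higher number a weaker inhibitor), compound 1 `CC(=O)N[C@@H](CSC/C=C(\C)CC/C=C(\C)CCC=C(C)C)C(=O)CCl` gives 3000 nM, compound 2 `CC(C)=CCC/C(C)=C/CC/C(C)=C/CSC[C@H](NC(=O)OC(C)(C)C)C(=O)CCl` gives 10700 nM, and compound 3 `CC(C)=CCC/C(C)=C/CC/C(C)=C/CSCC(=O)CCl` gives 84300 nM, the highest of the three numbers; against compound 3, compound 2 sits well lower and compound 1 lower still. Compound 4 `CC(C)=CCC/C(C)=C/CC/C(C)=C/CSCCC(=O)CCl` differs from compound 3 by ((chloromethyl)carbonyl)methyl in place of (chloromethyl)carbonyl on a saturated chain carbon bound to a sulfur. Among the measured compounds shown here, the only measured step, a 3.6-fold higher number from compound 1 to compound 2 (0.55 log units; beyond the scatter), concerns a part of the molecule that compound 3 and compound 4 both lack, so it does not bear on this change, and no measured pair alters the length of the chain carrying the chloromethyl ketone. With nothing to set a direction, compound 4 is expected to show a step of a 1.1-fold lower number from compound 3 to compound 4 (0.02 log units; within the scatter). For compound 4 the estimated value in this assay is 80000 nM, between 20000 nM and 300000 nM.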

Compound 4, half-maximal inhibitory concentration: 40700 nM
The estimate for compound 4 lay 2.0-fold (0.29 log units) above the measured number; the range from low to high includes it.
By their numbers in this assay, from the lowest: compound 1; then compound 2; then compound 4; then compound 3.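

In this assay the change to ((chloromethyl)carbonyl)methyl on a saturated chain carbon bound to a sulfur gives a 2.1-fold lower number from compound 3 to compound 4 (0.32 log units; beyond the scatter) and so shows that this position responds, modestly, to the added carbon. The steps of a 3.8-fold higher number from compound 2 to compound 4 (0.58 log units; beyond the scatter) and a 14-fold higher number from compound 1 to compound 4 (1.13 log units; beyond the scatter) show that, with hydrogen in place of (tert-butoxycarbonyl)amino or acetamido, the added carbon still leaves a higher number than either group gives. Nothing available explains these steps. On these data alone, whether a still longer chain continues this direction stays open, as does the effect of an amine or a carboxylic acid in place of acetamido.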